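The source may hold more compounds than are shown below. What is called first, only, known or untested is meant among the compounds shown, and "the series" means these compounds.

Measured so far:
compound 1, `Cc1ccccc1C(=O)Nc1ccc2nc(NC(=O)C3CCCCC3)sc2c1`: 0.085 ug/mL
compound 2, `CCCC(C)C(=O)Nc1ccc2nc(NC(=O)C3CCCCC3)sc2c1`: 0.14 ug/mL
compound 3, `CCC(C)(C)C(=O)Nc1ccc2nc(NC(=O)C3CCCCC3)sc2c1`: 1 ug/mL

In a functional assay on WI-38 VA13 cells (Homo sapiens) for cytotoxicity (on this read-out lower numbers stand for an effect already at smaller amounts and higher numbers for an effect only at larger amounts of compound), compound 3 stands at the highest number of the three: a 7.1-fold higher number from compound 2 to compound 3 (0.85 log units; beyond the scatter), and a 12-fold higher number from compound 1 to compound 3 (1.07 log units; beyond the scatter). The other two numbers lie within the scatter of each other, a 1.6-fold higher number from compound 1 to compound 2 (0.22 log units; within the scatter).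

Compound 4, `C=CCOC(=O)Nc1ccc2nc(NC(=O)C3CCCCC3)sc2c1`, is not yet measured in this assay. It differs from compound 3 in one place: allyloxy in place of 1,1-dimethylpropyl on a carbonyl carbon. Going by the values given here, no measured pair covers this change. The two steps that lead into compound 3 both put 1,1-dimethylpropyl in place of another group on the carbonyl carbon and both raise the number beyond the scatter, so the group that leaves here is the one tied to the highest number seen. On that basis a lower number than for compound 3 is expected, though the size is uncertain, estimated as a 3.3-fold lower number from compound 3 to compound 4 (0.52 log units; beyond the scatter). For compound 4 the estimate in this assay is 0.3 ug/mL, with a range from 0.05 ug/mL to 3 ug/mL.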

Compound 4, half-maximal effective concentration: 0.58 ug/mL
Compound 4: the middle estimate sits 1.9-fold (0.29 log units) below what was measured; the measured number falls inside the stated range.
By their numbers in this assay, from the lowest: compounds 1 and 2 (each within the scatter of the next); then compounds 4 and 3 (each within the scatter of the next).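

In this assay, going by these compounds alone, allyloxy on the carbonyl carbon, the first group at this place with an oxygen and a hydrogen-bond acceptor, cannot be told apart from 1,1-dimethylpropyl (a 1.7-fold lower number from compound 3 to compound 4 (0.24 log units; within the scatter)). It stays clearly separate from the groups in the two lowest compounds (a 4.1-fold higher number from compound 2 to compound 4 (0.62 log units; beyond the scatter); a 6.8-fold higher number from compound 1 to compound 4 (0.83 log units; beyond the scatter)), so the high end of this position now holds two quite different groups rather than the 1,1-dimethylpropyl group alone. Nothing available explains this grouping of the four compounds.

Open, going by these compounds, is whether the oxygen or the double bond of allyloxy goes with the higher number, which a propoxy group, its saturated counterpart, or a pentyl chain could help separate. Also open, on these data alone, is how this place responds to an amine or a carboxylic acid on the carbonyl carbon's substituent.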